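The compounds below may be only part of what the source reports. "The series", "measured", "known", "first", "only" and "open" are said of these compounds alone.

Compound 2 `CC1CCN(C2CCN(S(=O)(=O)c3ccc(C#N)cc3)CC2)CC1` carries a 4-cyanophenyl group on the sulfonyl sulfur of the shared core. In a functional assay on DLD-1 cells (Homo sapiens) for antiproliferative activity, read by CellTiter-Glo, with a stated time of 72 h (on this read-out lower numbers stand for stronger inhibition and higher numbers for weaker inhibition), compound 2 gives 2800 nM. Compound 3 `CCCCOc1ccc(S(=O)(=O)N2CCC(N3CCC(C)CC3)CC2)cc1` gives 2300 nM in this assay, separated from compound 2 by a 1.2-fold lower number from compound 2 to compound 3 (0.09 log units; within the scatter), within the scatter. Of the two numbers shown, that of compound 2 is the larger figure, but the gap to compound 3 is within the scatter, so the two count as alike. Compound 1 `CC1CCN(C2CCN(S(=O)(=O)c3cn(C)cn3)CC2)CC1` gives only a limit in this assay, > 5000 nM, and not a number. Compound 4 `CC1CCN(C2CCN(S(=O)(=O)c3cc(Cl)cc(Cl)c3)CC2)CC1` differs from compound 2 by 3,5-dichlorophenyl in place of 4-cyanophenyl on a sulfonyl sulfur. For the measured compounds named here, two measured steps bear on changing the group on the sulfonyl sulfur: an at least 1.7-fold lower number from compound 1 to compound 2 (0.25 log units; that floor lies within the scatter) starts from a limit, and its floor lies within the scatter; a 1.2-fold lower number from compound 2 to compound 3 (0.09 log units; within the scatter) is also within the scatter. Neither step moves the number beyond the scatter, so a small step in either direction is expected. Compound 4 is therefore estimated to give 2200 nM, with a range from 800 nM to 6000 nM, an expected step of a 1.3-fold lower number from compound 2 to compound 4 (0.10 log units; within the scatter) within the scatter.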

Compound 4, half-maximal inhibitory concentration: 3400 nM
Estimate against measurement, compound 4: 1.5-fold (0.19 log units) below, within the range that was stated.
By their numbers in this assay, from the lowest: compounds 3, 2 and 4 (each within the scatter of the next). At a limit, above all of these: compound 1.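

Replacing 4-cyanophenyl with 3,5-dichlorophenyl on the sulfonyl sulfur gives a 1.2-fold higher number from compound 2 to compound 4 (0.08 log units; within the scatter) in this assay, so losing the nitrile and gaining two chlorine atoms does not measurably change the result. Until now, the phenyl compounds, compound 2 and compound 3, each carried a single group on the ring, and compound 4 shows that a ring with two chlorine atoms also stays within the scatter of compound 2. Read from a limit, an at least 1.4-fold lower number from compound 1 to compound 4 (0.16 log units; that floor lies within the scatter) is only a floor, and compound 1 offers no true number for comparison: the limit of > 5000 nM in this assay, at which 1 of the 4 values shown sits.

Going by these compounds, it remains open whether any group on the sulfonyl sulfur can move the number beyond the scatter. A phenyl ring carrying an amine or a carboxylic acid, or a chain longer than butoxy, would test this.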